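This account rests on a few compounds, and the source may have more. Where it says the series, first, only, none or still open, it means among the compounds named here.

Series so far, dose values in a functional assay on the whole organism (strain Sprague-Dawley) for inhibition, with Rattus norvegicus as the target, with a stated time of 10 min; on this read-out lower numbers stand for an effect already at smaller amounts and higher numbers for an effect only at larger amounts of compound:
- compound 1 `CCOC(=O)c1cnc(-c2ccccc2OCC)[nH]c1=O`: 2 mg/kg
- compound 2 `CCOC(=O)C(=O)Nc1ccc(OCC)c(-c2ncc(C(=O)OCC)c(=O)[nH]2)c1`: 5 mg/kg

Of these two numbers, compound 2 holds the higher at 5 mg/kg, and compound 1 the lower at 2 mg/kg. The next compound to be read is compound 3 `CCOC(=O)c1cnc(-c2cc(S(N)(=O)=O)ccc2OCC)[nH]c1=O`. It carries sulfamoyl in place of ((ethoxycarbonyl)carbonyl)amino on an aromatic carbon, meta to a large group and para to an ethoxy group: sulfamoyl in place of ((ethoxycarbonyl)carbonyl)amino on an aromatic carbon.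

Among the compounds with values here, only one measured step bears on this position: a 2.5-fold higher number from compound 1 to compound 2 (0.40 log units; beyond the scatter), where ((ethoxycarbonyl)carbonyl)amino replaced hydrogen. That step is modest, though beyond the scatter. Within the data shown here, no measured compound carries sulfamoyl, so its own contribution remains unknown. Compound 3 is therefore expected to lie near the two measured numbers in this assay, with the uncertainty wide on a single step. The estimated change is a 1.7-fold lower number from compound 2 to compound 3 (0.22 log units; within the scatter), a slight move toward lower numbers and not expected to exceed the scatter. For compound 3 the estimated dose is 3 mg/kg, with an expected range from 0.8 mg/kg to 10 mg/kg.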

Compound 3, dose for 50% inhibition: 50 mg/kg
Compound 3: the middle estimate sits 17-fold (1.22 log units) below what was measured, outside the stated range (above it).
By their numbers in this assay, from the lowest: compound 1; then compound 2; then compound 3.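

In this assay, the aromatic carbon para to an ethoxy group proves far more sensitive to its substituent than the earlier pair suggested: sulfamoyl in place of hydrogen gives a 25-fold higher number from compound 1 to compound 3 (1.40 log units; beyond the scatter), while ((ethoxycarbonyl)carbonyl)amino there gave only a 2.5-fold higher number from compound 1 to compound 2 (0.40 log units; beyond the scatter). Exchanging one group for the other gives a 10-fold higher number from compound 2 to compound 3 (1.00 log units; beyond the scatter), so the number does not rise with group size across these three compounds: sulfamoyl is the smaller substituent by heavy-atom count, yet compound 3 stands further from compound 1 than compound 2 does. No measurement at hand accounts for this difference between the two groups.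

Going by these compounds, it remains open whether the high number follows the sulfamoyl group as a whole or some part of it, which a methylsulfonyl group or an N-methylsulfamoyl group on the same carbon would help to separate. On these data alone, it is equally open how much of the milder step belongs to the ethyl ester end of ((ethoxycarbonyl)carbonyl)amino, a question that a simple acetylamino group or a free amine at this position would address.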